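Benzylsulfanyl to methylamino on a uridine diphosphate core

The compounds below may be only part of what the source reports. "The series", "measured", "known", "first", "only" and "open" are said of these compounds alone.

Compound 3 `O=c1ccn([C@@H]2O[C@H](COP(=O)(O)OP(=O)(O)O)[C@@H](O)[C@H]2O)c(SCc2ccccc2)n1` gives 6200 nM in an in vitro functional assay on 1321-N1 cells for agonist activity at P2Y purinoceptor 2 (Homo sapiens), read by scintillation proximity assay and inositol phosphate accumulation (on this read-out higher numbers stand for an effect only at larger amounts of compound and lower numbers for an effect already at smaller amounts), the highest of the two plain numbers in this set; its nearest neighbour is compound 1 `O=c1ccn([C@@H]2O[C@H](COP(=O)(O)OP(=O)(O)O)[C@@H](O)[C@H]2O)c(SCCc2ccccc2)n1`, which in this assay gives 544 nM. The change between them, phenyl in place of benzyl on a saturated chain carbon bound to a sulfur, produced the step of an 11-fold higher number from compound 1 to compound 3 (1.06 log units; beyond the scatter). Compound 2 `CNc1nc(=O)ccn1[C@@H]1O[C@H](COP(=O)(O)O)[C@@H](O)[C@H]1O` gives in this assay only a limit of the assay, > 100000 nM, as noted at the limit of > 100000 nM in this assay, at which 1 of the 3 values shown sits. Compound 4 `CNc1nc(=O)ccn1[C@@H]1O[C@H](COP(=O)(O)OP(=O)(O)O)[C@@H](O)[C@H]1O` is obtained from compound 3 by the change (methylamino in place of benzylsulfanyl on an aromatic carbon). Within the data shown here, no measured step covers this exchange; the only comparison of this kind is compound 2, which carries the same methylamino group and yields a limit rather than a number. Compound 4 is therefore expected to give a higher number than compound 3, an estimated step of a 3.2-fold higher number from compound 3 to compound 4 (0.51 log units; beyond the scatter). The value of compound 4 in this assay is estimated at 20000 nM, with a range from 3000 nM to 100000 nM.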

Compound 4, half-maximal effective concentration: 7600 nM
For compound 4 the middle estimate is 2.6-fold (0.42 log units) above the measured one; low and high end bracket the measured number.
By their numbers in this assay, from the lowest: compound 1; then compounds 3 and 4 (each within the scatter of the next). At a limit, above all of these: compound 2.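

Placed on an aromatic carbon between two ring nitrogen atoms, methylamino in place of benzylsulfanyl gives a 1.2-fold higher number from compound 3 to compound 4 (0.09 log units; within the scatter), so in this assay a group of 2 heavy atoms with no ring cannot be told apart from one of 8 heavy atoms carrying a six-membered aromatic ring. Phenethylsulfanyl alone stands apart, since methylamino in its place gives a 14-fold higher number from compound 1 to compound 4 (1.15 log units; beyond the scatter). A group of 4 heavy atoms (3 oxygen, 1 phosphorus) in place of a hydrogen atom on an oxygen gives an at least 13-fold lower number from compound 2 to compound 4 (1.11 log units; beyond the scatter), but that step starts from a limit and not from a number: the limit of > 100000 nM in this assay, at which 1 of the 4 values shown sits.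

The compounds shown leave open how a plain amine or a phenethylamino group would behave at this position. They also leave open whether a longer chain on the sulfur would give a lower number than phenethylsulfanyl.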